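The source may report more compounds than this note shows. Statements on the series, on what has been measured and on what is new or still open speak of the compounds shown alone.

Working notes on three compounds measured in a functional assay for antagonist activity at Melanocortin receptor 4 (Homo sapiens), read by cAMP accumulation; a lower number here means a stronger inhibitor, a higher number a weaker inhibitor. Compound 2 `COc1ccc(Br)cc1CCc1c(F)cccc1C(=O)/N=C(\N)NCCN1CCCC1` stands highest of the three numbers, at 4500 nM. Compound 1 `CCN(CC)CCCC(C)/N=C(/N)NC(=O)c1cccc(F)c1OCc1cc(Br)ccc1OC` gives 530 nM, and compound 3 `COc1ccc(Br)cc1CCc1c(F)cccc1C(=O)/N=C(\N)NCCCN1CCCCC1` gives 330 nM. Among the measured compounds shown here, only one step between single-point neighbours is available, the one from compound 2 to compound 3 a 14-fold lower number from compound 2 to compound 3 (1.13 log units; beyond the scatter); it shows that the chain carried on the amine nitrogen moves the number in this assay by a large margin.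

Compound 4 `COc1ccc(Br)cc1CCc1c(F)cccc1C(=O)/N=C(\N)NCC(C)C` differs from compound 2 in that same chain: isopropyl in place of (pyrrolidin-1-yl)methyl on a saturated chain carbon bound to an amine nitrogen. For the measured compounds named here, no measured pair tests this change directly. Compound 1 and compound 3 each keep a saturated ring at the end of the chain, so the step from compound 2 to compound 3 bears on it only by showing how far a change in this chain can shift the number, not in which direction. The expectation for compound 4 is a further rise beyond the scatter, a 3.3-fold higher number from compound 2 to compound 4 (0.52 log units; beyond the scatter). Compound 4 is estimated at 15000 nM, with a range from 3000 nM to 60000 nM.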

Compound 4, half-maximal inhibitory concentration: 8500 nM
The estimate for compound 4 lay 1.8-fold (0.25 log units) above the measured number; the measured number falls inside the stated range.
By their numbers in this assay, from the lowest: compounds 3 and 1 (each within the scatter of the next); then compounds 2 and 4 (each within the scatter of the next).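

In this assay, isopropyl in place of (pyrrolidin-1-yl)methyl gives a 1.9-fold higher number from compound 2 to compound 4 (0.28 log units; within the scatter), so a chain ending in the pyrrolidin-1-yl ring and one ending without a ring or a second amine nitrogen cannot be told apart here. The low number of compound 3 therefore does not follow from any ring-bearing chain, and the same chain position also gives a 26-fold higher number from compound 3 to compound 4 (1.41 log units; beyond the scatter), so the 2-(piperidin-1-yl)ethyl chain of compound 3 is what separates it from compound 4. No supporting measurement bears on why these chains differ.

Chain length and ring size change together from compound 2 to compound 3, so their shares remain unresolved. A piperidin-1-yl group on the shorter chain, a pyrrolidin-1-yl group on the longer chain, or a dimethylamino group at the end of the longer chain would separate these contributions.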